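A Fluorine on the Core of Compound 3

The source may report more compounds than this note shows. Statements on the series, on what has been measured and on what is new or still open speak of the compounds shown alone.

Three compounds share one core and differ only in the group on the amine nitrogen. Compound 1 `CNS(=O)(=O)NC[C@@H]1CCCc2cc(S(=O)(=O)c3cccc(F)c3)ccc21` gives 1 nM in an assay on isolated protein for displacement of a labelled ligand from 5-hydroxytryptamine receptor 6 (Homo sapiens); a lower number here means a stronger inhibitor, a higher number a weaker inhibitor. Compound 2 `O=C(NC[C@@H]1CCCc2cc(S(=O)(=O)c3cccc(F)c3)ccc21)c1ccc[nH]1` gives 5.01 nM in this assay. Compound 3 `O=S(=O)(c1cccc(F)c1)c1ccc2c(c1)CCC[C@H]2CNCCO` gives 0.126 nM in this assay, the lowest of the three numbers: a 7.9-fold lower number from compound 1 to compound 3 (0.90 log units; beyond the scatter) and a 40-fold lower number from compound 2 to compound 3 (1.60 log units; beyond the scatter) both lie beyond the scatter, while a 5.0-fold higher number from compound 1 to compound 2 (0.70 log units; beyond the scatter) is modest.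

Compound 4 `O=S(=O)(c1cccc(F)c1)c1cc(F)c2c(c1)CCC[C@H]2CNCCO` keeps the 2-hydroxyethyl group of compound 3 and alters the core instead: fluoro in place of hydrogen on an aromatic carbon, on an aromatic carbon of a six-membered aromatic ring of carbon only, part of a fused system of two rings, ortho to a fused ring, meta to a fused ring and meta to a large group. None of the three measured steps touches the aromatic ring; all change the group on the amine nitrogen, so none bears directly on this change. Because compound 3 gives 0.126 nM and the core is otherwise untouched, compound 4 is expected to stay near it, with an estimated step of a 1.2-fold higher number from compound 3 to compound 4 (0.08 log units; within the scatter) not beyond the scatter. In this assay compound 4 is estimated at 0.15 nM, within a range from 0.05 nM to 0.5 nM.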

Compound 4, inhibition constant: 0.159 nM
For compound 4 the middle estimate is 1.1-fold (0.03 log units) below the measured one; measured number inside the range.
By their numbers in this assay, from the lowest: compounds 3 and 4 (each within the scatter of the next); then compound 1; then compound 2.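

For the compounds shown here, until now every step had changed the group on the amine nitrogen, so this is the first reading of a change on the aromatic ring of the shared core. In this assay, fluoro in place of hydrogen on an aromatic carbon gives a 1.3-fold higher number from compound 3 to compound 4 (0.10 log units; within the scatter). With the 2-hydroxyethyl group on the amine nitrogen, this position, ortho to a fused ring and meta to a large group, therefore accepts the fluorine with no difference that can be told from the scatter, and no evidence at hand bears on this result.

On these data alone, it remains open whether a larger group at this position, such as chloro, methoxy or nitrile, would give a similar number. As far as these compounds go, it is also open whether fluoro here would read the same with methylsulfamoyl or (1H-pyrrol-2-yl)carbonyl on the amine nitrogen.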